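A few compounds are considered here, and "the series" means these few. Any claim that something is new, unique, unknown or untested is made for them only; others in the source may bear on it.

In a functional assay on ECa-109 cells for inhibition, with ECa-109 cell line (Homo sapiens) as the target, read by sulforhodamine B assay (a lower number here means a stronger inhibitor, a higher number a weaker inhibitor), compound 1 `O=C1C=C(NCc2ccccc2)C(=O)c2c1nc1n2[C@H]2OC[C@@H](O)[C@H]2OC1` gives > 8000 nM as a limit. Compound 2 `O=C1C=C(NC2CCCC2)C(=O)c2c1nc1n2[C@H]2OC[C@@H](O)[C@H]2OC1` gives > 16000 nM as a limit too, so it has no number to start from. Compound 3 `O=C1C=C(Nc2ccc(Br)cc2)C(=O)c2c1nc1n2[C@H]2OC[C@@H](O)[C@H]2OC1` carries 4-bromophenyl in place of cyclopentyl on an amine nitrogen. Going by the values given here, the only measured step offers no size to carry over because of a step that the two limits leave unreadable from compound 1 to compound 2 and it concerns a different pair of groups. Weak inhibition is still expected, with no firm direction, and the estimated change is an at least 1.3-fold lower number from compound 2 to compound 3 (0.12 log units; that floor lies within the scatter) for now. The estimate for compound 3 is 12000 nM with an expected range from 3000 nM to 32000 nM in this series.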

Compound 3, half-maximal inhibitory concentration: 2850 nM
Compound 3: the middle estimate sits 4.2-fold (0.62 log units) above what was measured; the whole stated range lies above it.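

In this assay, 4-bromophenyl on the amine nitrogen gives the first readable potency in this set, with an at least 5.6-fold lower number from compound 2 to compound 3 (0.74 log units; beyond the scatter) and an at least 2.8-fold lower number from compound 1 to compound 3 (0.44 log units; beyond the scatter). Compound 2 stands at a limit, so the first step is only a floor: the limit of > 16000 nM in this assay, at which 1 of the 3 values shown sits. Compound 1 also stands at a limit, so the second step is likewise only a floor: the limit of > 8000 nM in this assay, at which 1 of the 3 values shown sits. From the compounds shown here alone, whether the gain rests on the phenyl ring or on the bromine remains open. Plain phenyl, or chlorine or methoxy in place of the bromine, would separate the two.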